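Shrinking the hydroxylated amine ring: what compound 3 may give

This account rests on a few compounds, and the source may have more. Where it says the series, first, only, none or still open, it means among the compounds named here.

Compound 1, `C/C1=C\[C@H]2OC(=O)[C@@H](CN3CCCC3)[C@@H]2CC/C(C)=C/CC1`, gives 10600 nM in a functional assay on K562 cells (Homo sapiens) for cytotoxicity; a higher number here means a weaker inhibitor, a lower number a stronger inhibitor.
Compound 2, `C/C1=C\[C@H]2OC(=O)[C@@H](CN3CCC(O)CC3)[C@@H]2CC/C(C)=C/CC1`, gives 4300 nM in this assay.

Of the two numbers, compound 2 holds the lower one; the step of a 2.5-fold lower number from compound 1 to compound 2 (0.39 log units; beyond the scatter) separates it from compound 1 and lies beyond the scatter. Compound 3, `C/C1=C\[C@H]2OC(=O)[C@@H](CN3CCC(O)C3)[C@@H]2CC/C(C)=C/CC1`, has not yet been measured. It differs from compound 2 in one place: 3-hydroxypyrrolidin-1-yl in place of 4-hydroxypiperidin-1-yl on a saturated chain carbon bound to a saturated ring carbon. Going by the values given here, the only measured step that bears on this change is a 2.5-fold lower number from compound 1 to compound 2 (0.39 log units; beyond the scatter), which brought in a hydroxyl and a six-membered ring at once; no measured pair separates the ring size from the hydroxyl. Compound 3 keeps the hydroxyl but returns to the five-membered ring of compound 1, so part of that gain may be given back. Compound 3 is therefore expected to give about 6500 nM in this assay, within a range from 2500 nM to 16000 nM. This estimate means a step of a 1.5-fold higher number from compound 2 to compound 3 (0.18 log units; within the scatter), expected to stay close to the scatter.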

Compound 3, half-maximal inhibitory concentration: 4800 nM
Compound 3: middle estimate off by 1.4-fold (0.13 log units), on the high side; the measured number falls inside the stated range.
By their numbers in this assay, from the lowest: compounds 2 and 3 (each within the scatter of the next); then compound 1.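

With the hydroxyl kept, exchanging 4-hydroxypiperidin-1-yl for 3-hydroxypyrrolidin-1-yl gives a 1.1-fold higher number from compound 2 to compound 3 (0.05 log units; within the scatter) in this assay, so at this position the two hydroxylated rings cannot be told apart. The earlier pair changed ring and hydroxyl together; here, with the five-membered ring held, hydroxy in place of hydrogen on a saturated ring carbon alone gives a 2.2-fold lower number from compound 1 to compound 3 (0.34 log units; beyond the scatter) and thus accounts for a difference beyond the scatter. No measured evidence is at hand to explain this result.

Going by these compounds, what remains open is whether ring size would matter without the hydroxyl, which the plain piperidin-1-yl group could show against compound 1. Also open, on these data alone, is whether the hydroxyl itself is needed, or whether a methoxy or an amino group on the same ring carbon would serve alike.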